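The source may hold more compounds than are shown below. What is called first, only, known or untested is meant among the compounds shown, and "the series" means these compounds.

Working notes on the series.

Compound 1 `O=[N+]([O-])c1ccc(-c2csc(N/N=C/c3ccc(C(F)(F)F)cc3)n2)cc1` and compound 2 `O=[N+]([O-])c1cccc(-c2csc(N/N=C/c3ccc(C(F)(F)F)cc3)n2)c1` share one core and differ only in the nitrophenyl attached to it. Compound 1 gives only a limit in a functional assay on HT-29 cells (Homo sapiens) for inhibition, read by MTT assay, with a stated time of 72 h (a lower number here means a stronger inhibitor, a higher number a weaker inhibitor), > 63500 nM. Among the measured compounds shown here, compound 2 in this assay gives 23900 nM, the sole full number in the set so far. The other entry, that of compound 1, is a limit (the limit of > 63500 nM in this assay, at which 1 of the 2 values shown sits). For the measured compounds named here, the one measured step, an at least 2.6-fold lower number from compound 1 to compound 2 (0.42 log units; beyond the scatter), shows that the position of the nitro group on the phenyl matters by a margin outside the scatter.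

Compound 3 `FC(F)(F)c1ccc(/C=N/Nc2nc(-c3ccc(Cl)cc3Cl)cs2)cc1` has not yet been measured. Relative to compound 2 the change is 2,4-dichlorophenyl in place of 3-nitrophenyl on an aromatic carbon. Going by the values given here, no measured step swaps the nitro group for chlorine atoms or moves from a phenyl with acceptors to one without, so the step from compound 1 to compound 2 does not bear on this change directly; it only shows the phenyl on the core is a sensitive site. Among the compounds with values here, with no matching step, no change beyond the scatter is expected. The expected step is a 1.2-fold lower number from compound 2 to compound 3 (0.08 log units; within the scatter). Compound 3 is therefore estimated at 20000 nM in this assay, within 6000 nM to 63500 nM.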

Compound 3, half-maximal inhibitory concentration: 11200 nM
Beside the measured number, compound 3's estimate is 1.8-fold (0.25 log units) above it; low and high end bracket the measured number.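

In this assay, the step of a 2.1-fold lower number from compound 2 to compound 3 (0.33 log units; beyond the scatter) shows that this position on the shared core accepts more than a shift of the nitro group: the whole 3-nitrophenyl can give way to 2,4-dichlorophenyl, a group with no hydrogen-bond acceptors, and the number still falls by a margin beyond the scatter. Measured against the 4-nitrophenyl, the change gives an at least 5.6-fold lower number from compound 1 to compound 3 (0.75 log units; beyond the scatter), so compound 3 holds the lowest number of the three, with both of its steps beyond the scatter. The value of compound 1 is a limit and not a number, so that second step is only a bound: the limit of > 63500 nM in this assay, at which 1 of the 3 values shown sits.

The step from the 3-nitrophenyl to 2,4-dichlorophenyl removes the nitro group and brings in both chlorine atoms at once, so the compounds shown do not tell what each chlorine atom contributes alone. Also open, on these data alone, is how the number would move with an unsubstituted phenyl at this position, or with an amine or a carboxylic acid on the phenyl.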